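Three cytotoxicity limits and one estimate for compound 4

The compounds below may be only part of what the source reports. "The series", "measured", "known", "first", "only" and "open" are said of these compounds alone.

Three compounds on a shared core have been tested in an ADME assay on Vero cells (Chlorocebus sabaeus) for cytotoxicity, read by resazurin assay, with a stated time of 3 days; a higher number here means a weaker inhibitor, a lower number a stronger inhibitor:

Compound 1, `CCN(CC)c1cc2[nH]c(C3CCCCC3)nc2cc1NC(=O)c1ccc(OC(F)F)cc1`: > 100 ug/mL, a limit.
Compound 2, `CCN(CC)c1cc2[nH]c(C3CCCCC3)nc2cc1NC(=O)OCCOCCOC`: > 100 ug/mL, a limit.
Compound 3, `CCN(CC)c1cc2[nH]c(C3CCCCC3)nc2cc1NC(=O)c1ccc(Br)cc1`: > 100 ug/mL, a limit.

Compound 3 therefore stands at the limit of > 100 ug/mL in this assay, at which 3 of the 3 values shown sit, and the two other values shown are limits as well. The step that the two limits leave unreadable from compound 1 to compound 3, the step that the two limits leave unreadable from compound 1 to compound 2 and the step that the two limits leave unreadable from compound 2 to compound 3 all remain unreadable, since each pair of values is a pair of limits.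

Compound 4, `CCN(CC)c1cc2[nH]c(C3CCCCC3)nc2cc1NC(=O)c1ccc(F)cc1F`, has not been measured. It differs from compound 3 in one place: 2,4-difluorophenyl in place of 4-bromophenyl on a carbonyl carbon. Among the compounds with values here, none of the measured steps gives a readable size, so no direction can be drawn from them; what they do show is that three amide and carbamate variants on this core all sit at the same limit. The expectation for compound 4 in this assay is therefore a step of a number no higher from compound 3 to compound 4 (the limit leaves the size open) from compound 3 that is none beyond the scatter, with compound 4 again most likely reported as a limit. The estimated value for compound 4 is 100 ug/mL, with an expected range from 50 ug/mL to 200 ug/mL.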

Compound 4, half-maximal inhibitory concentration: > 100 ug/mL
Compound 4 was reported as a limit (the forecaster's own chance of this, stated with the estimate: 85%); the middle value sits exactly at the limit.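

Compound 4 is reported as a limit too, so the steps to it from compound 1, compound 2 and compound 3 cannot be read: the limit of > 100 ug/mL in this assay, at which 4 of the 4 values shown sit.

The compounds shown leave open how far their true values in this assay lie from one another, and which change on the shared core, if any, would give a number rather than a limit.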